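The source may hold more compounds than are shown below. What is called first, only, known or untested is meant among the compounds shown, and "the series" means these compounds.

Measured compounds:
- compound 1, `C[C@H](Nc1ncnc2[nH]cnc12)c1nn(-c2ccccn2)c2cc(F)ccc12`: 22%
- compound 2, `C[C@H](Nc1ncnc2[nH]cnc12)c1nn(-c2cc(F)cc(F)c2)c2cc(F)ccc12`: 30%

Within the data shown here, in a functional assay on HepG2 cells (Homo sapiens) for inhibition, read by sulforhodamine B assay, with a stated time of 72 h, tested at 10 uM (a lower number here means less inhibition, a higher number more inhibition at the concentration tested (going by the name of the read-out)), compound 2 stands highest of the two numbers, but its only neighbour, compound 1, lies close: the step of a number 8 percentage points higher from compound 1 to compound 2 (within the scatter) sits within the usual scatter, so the two compounds cannot be told apart on these data. Compound 3, `C[C@H](Nc1ncnc2[nH]cnc12)c1nn(-c2ccncc2)c2cc(F)ccc12`, is the next compound to be tested. It differs from compound 2 in one place: pyridin-4-yl in place of 3,5-difluorophenyl on an aromatic nitrogen.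

Among the measured compounds shown here, the one measured step bears directly on this change, since it also exchanged the six-membered aromatic ring on the same aromatic nitrogen of the shared core, pyridin-2-yl giving way to 3,5-difluorophenyl, and the read-out in this assay barely moved. The new exchange again replaces that ring, now with pyridin-4-yl. With a single comparable step that stayed within the scatter, no movement beyond the scatter is expected here either. The step expected is a number 5 percentage points lower from compound 2 to compound 3 (within the scatter). Compound 3 is therefore estimated at 25%, with a likely range from 10% to 40%.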

Compound 3, a percentage reported as inhibition, at one concentration (the size of the read-out at that concentration, not a potency): 47%
The estimate for compound 3 lay 22 percentage points below the measured number; the measured number lies above the stated range.
By their numbers in this assay, from the lowest: compounds 1 and 2 (each within the scatter of the next); then compound 3.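

this assay shows that the group on this aromatic nitrogen can move the result, since pyridin-4-yl gives a number 17 percentage points higher from compound 2 to compound 3 (beyond the scatter) and a number 25 percentage points higher from compound 1 to compound 3 (beyond the scatter) while the earlier exchange at this place produced no readable change. The second step is the more telling one: both groups are pyridine rings, so the place of the ring nitrogen within the group is all that separates compound 1 from compound 3, and the mere presence of a ring nitrogen does not go with a higher number, as compound 1 with its pyridin-2-yl group stays within the scatter of compound 2, whose 3,5-difluorophenyl ring is carbon only. No measurement offered alongside these numbers explains why this one group stands apart.

On these data alone, whether pyridin-3-yl would read like pyridin-4-yl or like pyridin-2-yl stays open, and so does the outcome with a plain phenyl ring or a saturated ring such as morpholine in this place. As far as these compounds go, a reading at one concentration is also not a potency, so the higher number of compound 3 does not tell what concentration of each compound would be needed for a given effect, which remains unknown.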